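The compounds below may be only part of what the source reports. "The series", "measured", "known", "first", "only" and "open" are said of these compounds alone.

Measured so far:
compound 1, `COc1cc(CNCc2ccncc2)ccc1OCc1ccc(F)cc1`: 6400 nM
compound 2, `COc1cc(CNCC2CCCO2)ccc1OCc1ccc(Cl)nc1`: 66000 nM
compound 3, `COc1cc(OCc2ccc(Cl)cc2)ccc1CNCc1ccncc1`: 440 nM

All three were tested in a functional assay on HeLa cells (Homo sapiens) for inhibition, with a stated time of 72 h; on this read-out lower numbers stand for an effect already at smaller amounts and higher numbers for an effect only at larger amounts of compound. Compound 2 stands at the highest number of the three: compound 1 sits lower by a gap beyond the usual scatter, and compound 3 lies lower still, further from compound 2 than compound 1 is. Within the data shown here, the three compounds differ from one another in more than one place, so no single step between them can be read off, and nothing in the numbers for compounds 1 and 3 can be traced to one change alone.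

Compound 4, `COc1cc(CNCc2cccs2)ccc1OCc1ccc(Cl)nc1`, has not been measured yet. It differs from compound 2 in one place: thiophen-2-yl in place of oxolan-2-yl on a saturated chain carbon bound to an amine nitrogen. Among the measured compounds shown here, no measured pair shows this particular exchange, so its size is not known from the data. The expectation rests only on the wider picture, in which compound 2 gives the highest number, compound 1 gives 6400 nM and compound 3 gives 440 nM. On that basis a moderate step downward, beyond the scatter, is expected, and a 6.6-fold lower number from compound 2 to compound 4 (0.82 log units; beyond the scatter) is the estimated step. Compound 4 is therefore expected to give about 10000 nM, with a range from 2500 nM to 40000 nM.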

Compound 4, half-maximal effective concentration: 96000 nM
Compound 4: the middle estimate sits 9.6-fold (0.98 log units) below what was measured; the whole stated range lies below it.
By their numbers in this assay, from the lowest: compound 3; then compound 1; then compounds 2 and 4 (each within the scatter of the next).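

In this assay, among these compounds, putting thiophen-2-yl in place of oxolan-2-yl on a saturated chain carbon bound to an amine nitrogen gives a 1.5-fold higher number from compound 2 to compound 4 (0.16 log units; within the scatter), and this is the first step here that can be read at a single place. At this position, then, a five-membered non-aromatic ring with oxygen and a five-membered aromatic ring with sulfur, each with the same number of heavy atoms, cannot be told apart on this read-out, so this exchange does not by itself bring the number down on the core that compound 2 and compound 4 share. The data offer no separate measurement that could explain why the two rings read alike.

Going by these compounds, whether a carboxylic acid, a plain phenyl ring or a longer chain at this same place would shift the number beyond the scatter remains open. Also open, on these data alone, is whether the same exchange would read alike on the core of compound 3, where the rest of the molecule differs.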